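Swapping methoxy for chloro on the benzyl arm

The source may report more compounds than this note shows. Statements on the series, on what has been measured and on what is new or still open speak of the compounds shown alone.

The compounds here share a core in which two indole rings are joined through a nitrile-bearing unsaturated ketone, and they are compared in a functional assay on MIA PaCa-2 cells (Homo sapiens) for cytotoxicity, read by WST assay, with a stated time of 48 h; a lower number here means a stronger inhibitor, a higher number a weaker inhibitor. Compound 2 has the structure `COc1ccc(Cn2cc(/C=C(\C#N)C(=O)c3c[nH]c4cc(OC)ccc34)c3ccccc32)cc1`. In this assay compound 2 reaches only the limit of > 50000 nM, so no number is known for it. Compound 1, with the structure `N#C/C(=C\c1cn(Cc2ccc(Cl)cc2)c2ccccc12)C(=O)c1c[nH]c2ccccc12`, also stands at a limit, giving > 50000 nM in this assay. For the measured compounds named here, compound 3, with the structure `COc1ccc2[nH]cc(/C=C(\C#N)C(=O)c3c[nH]c4ccccc34)c2c1`, is the one member with a measured number, at 25100 nM in this assay. As the evidence notes, (the limit of > 50000 nM in this assay, at which 2 of the 3 values shown sit), so most of what is known is a ceiling rather than a value.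

Compound 4, with the structure `COc1ccc2c(C(=O)/C(C#N)=C/c3cn(Cc4ccc(Cl)cc4)c4ccccc34)c[nH]c2c1`, has not yet been measured. It differs from compound 2 in one place: chloro in place of methoxy on an aromatic carbon. Going by the values given here, since no pair of measured compounds differs in only one place, no measured step guides this change. Compound 1 carries the same chlorobenzyl arm and sits at the same ceiling as compound 2, so the change is expected to move potency little, with the step from a step that the limit leaves unreadable from compound 2 to compound 4 expected to stay within the scatter. Compound 4 is therefore estimated at 60000 nM, within a range from 25000 nM to 150000 nM, and most likely to be reported only as a limit.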

Compound 4, half-maximal inhibitory concentration: 40400 nM
Compound 4: the middle estimate sits 1.5-fold (0.17 log units) above what was measured; the measured number falls inside the stated range.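

Read as 4-methoxybenzyl to 4-chlorobenzyl, the change gives an at least 1.2-fold lower number from compound 2 to compound 4 (0.09 log units; that floor lies within the scatter) and turns the limit held by compound 2 into a measured number in this assay for the chlorobenzyl compound. For the compounds shown here, the same result gives the first reading of methoxy in place of hydrogen on an aromatic carbon, with the chlorobenzyl arm kept, as an at least 1.2-fold lower number from compound 1 to compound 4 (0.09 log units; that floor lies within the scatter) for that single change. Neither step has a true size yet, only a floor, and much of this small set still gives no number: (the limit of > 50000 nM in this assay, at which 2 of the 4 values shown sit).

On these data alone, what remains open is whether either change does anything at all, and a true size for either step would need a measured number for compound 1 or compound 2 rather than a limit. The compounds shown also leave open how a benzyl arm carrying an amine or a carboxylic acid in place of chloro would compare with compound 4 in this assay under the same conditions.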